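Notes on the series: from compound 2 toward compound 3

The source may hold more compounds than are shown below. What is called first, only, known or untested is meant among the compounds shown, and "the series" means these compounds.

Measured so far:
compound 1, `CN(C(=O)NC(=O)c1ccc(Cl)cc1Cl)c1nc(C(F)(F)F)c(C(=O)N/N=C/c2ccccc2C(F)(F)F)s1`: 9.12 ug/mL
compound 2, `CN(C(=O)NC(=O)c1c(F)cccc1F)c1nc(C(F)(F)F)c(C(=O)N/N=C/c2ccccc2C(F)(F)F)s1`: 20.4 ug/mL
not yet measured: compound 3, `CN(C(=O)NC(=O)c1ccc(C(F)(F)F)cc1)c1nc(C(F)(F)F)c(C(=O)N/N=C/c2ccccc2C(F)(F)F)s1`

In a functional assay on MCF7 cells (Homo sapiens) for inhibition, read by MTT assay, with a stated time of 72 h (a lower number here means a stronger inhibitor, a higher number a weaker inhibitor), compound 1 gives 9.12 ug/mL and compound 2 gives 20.4 ug/mL. Compound 2 carries the highest number of the two measured; its nearest neighbour is compound 1, with a 2.2-fold higher number from compound 1 to compound 2 (0.35 log units; beyond the scatter).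

Compound 3 differs from compound 2 in one place: 4-(trifluoromethyl)phenyl in place of 2,6-difluorophenyl on a carbonyl carbon. Within the data shown here, the only measured step touching this position is the exchange of the aroyl group between compound 1 and compound 2, a 2.2-fold higher number from compound 1 to compound 2 (0.35 log units; beyond the scatter), a modest step beyond the scatter. Among the measured compounds shown here, that step shows the group on this carbonyl carbon matters to this assay, but 4-(trifluoromethyl)phenyl has no measured counterpart here, so direction is open. A small step, comparable in size to the one measured, is expected, more likely toward compound 1 than away from it.

For compound 3 the estimate in this assay is 13 ug/mL, range 5 ug/mL to 32 ug/mL, meaning a 1.6-fold lower number from compound 2 to compound 3 (0.20 log units; within the scatter) is expected.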

Compound 3, half-maximal inhibitory concentration: 2.21 ug/mL
The estimate for compound 3 lay 5.9-fold (0.77 log units) above the measured number; the measured number lies below the stated range.
By their numbers in this assay, from the lowest: compound 3; then compound 1; then compound 2.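

In this assay, the group on this carbonyl carbon has more influence than the first exchange showed: 4-(trifluoromethyl)phenyl in place of 2,6-difluorophenyl gives a 9.2-fold lower number from compound 2 to compound 3 (0.97 log units; beyond the scatter), a larger step than any seen before. The same group in place of 2,4-dichlorophenyl gives a 4.1-fold lower number from compound 1 to compound 3 (0.62 log units; beyond the scatter), so compound 3 is the strongest inhibitor of the three, and both dihalogenated phenyl groups give higher numbers than 4-(trifluoromethyl)phenyl. No evidence is available on what lies behind these differences.

The three compounds do not separate the contribution of the trifluoromethyl group from that of the halogens it replaces, a question that plain phenyl or a phenyl carrying a single chlorine or methoxy group would address. On these data alone, whether an aromatic ring is needed here at all also remains open, and a cyclohexyl group or a short alkyl chain on this carbonyl carbon would test that.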